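Acid in place of isopropyl on the acrylamide chain

The source may report more compounds than this note shows. Statements on the series, on what has been measured and on what is new or still open speak of the compounds shown alone.

Among the compounds with values here, compound 2, `CC(C)C/C(=C\C(=O)Nc1ccc2c(c1)OCCO2)c1ccc(C(C)(C)C)cc1`, holds the only number so far in a functional assay on CHO cells for inhibition of transient receptor potential cation channel subfamily V member 1 (Homo sapiens); a lower number here means a stronger inhibitor, a higher number a weaker inhibitor: compound 2 gives 94 nM. Compound 1, `CC(C)(C)c1ccc(C2CC2C(=O)Nc2ccc3c(c2)OCCO3)cc1`, is reported in this assay only as a limit, > 4000 nM, and that limit, (the limit of > 4000 nM in this assay, at which 1 of the 2 values shown sits), is all that is known of it. Compound 1 and compound 2 differ in more than one place, so the gap between them is not traced to a single change. Compound 3, `CC(C)(C)c1ccc(/C(=C/C(=O)Nc2ccc3c(c2)OCCO3)CCC(=O)O)cc1`, has not been measured; it differs from compound 2 by carboxymethyl in place of isopropyl on a saturated chain carbon bound to a double-bonded chain carbon, or isobutyl to 2-carboxyethyl when cut one bond further out. Within the data shown here, no measured pair carries this change, so the step is expected to weaken: a 16-fold higher number from compound 2 to compound 3 (1.20 log units; beyond the scatter) is the estimate, with a fair chance that only a limit is returned. Compound 3 is expected at 1500 nM, within 300 nM to 6000 nM.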

Compound 3, half-maximal inhibitory concentration: > 4000 nM
Compound 3 was reported as a limit; the forecaster's own chance of this, stated with the estimate: 30%; middle value at least 2.6-fold (0.42 log units) from the limit.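

Within the data shown here, on a saturated chain carbon bound to a double-bonded chain carbon, carboxymethyl in place of isopropyl gives the first single-place step in this assay: an at least 42-fold higher number from compound 2 to compound 3 (1.62 log units; beyond the scatter). Compound 3 stands only as a limit, > 4000 nM, so this step has a lower bound and no upper end. At this position, then, the number of compound 2 does not survive the change to 2-carboxyethyl, and further loss cannot be read at this end of the assay: the limit of > 4000 nM in this assay, at which 2 of the 3 values shown sit.

On these data alone, how a methyl ester, a primary amide or a 2-hydroxyethyl chain at this place would read against isobutyl remains open, and with it whether the step belongs to the carboxylic acid itself. As far as these compounds go, a 2-aminoethyl chain at the same place is equally open.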